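Pyrrolidin-1-yl in place of isopropylamino: working notes

The source may report more compounds than this note shows. Statements on the series, on what has been measured and on what is new or still open speak of the compounds shown alone.

Measured in an ADME assay on Akata cells (Homo sapiens) for cytotoxicity, with a stated time of 7 days (on this read-out lower numbers stand for higher toxicity in this test and higher numbers for lower toxicity in this test), so far:
- Compound 1 `CNc1nc(N)nc2c1ncn2/C=C1/CC1(CO)CO` gives > 24000 nM (a limit)
- Compound 2 `CCCSc1nc(N)nc2c1ncn2/C=C1/CC1(CO)CO` gives > 20000 nM (a limit)
- Compound 3 `CC(C)Nc1nc(N)nc2c1ncn2/C=C1/CC1(CO)CO` gives > 24000 nM (a limit)

Compound 3 has no number, only the limit > 24000 nM and nothing more can be said of its place. Compound 3 shares the limit of > 24000 nM in this assay, at which 2 of the 3 values shown sit, with compound 1. Compound 2 stands at the limit of > 20000 nM in this assay, at which 1 of the 3 values shown sits, instead. No ranking of the three is possible.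

The next compound is compound 4 `Nc1nc(N2CCCC2)c2ncn(/C=C3/CC3(CO)CO)c2n1` where pyrrolidin-1-yl replaces isopropylamino on an aromatic carbon pyrrolidin-1-yl in place of isopropylamino on an aromatic carbon in the core shared with compound 3.

Within the data shown here, three measured steps bear on this change, all at the same place on the core. They are a step that the two limits leave unreadable from compound 1 to compound 3 and a step that the two limits leave unreadable from compound 2 to compound 3 and a step that the two limits leave unreadable from compound 1 to compound 2 as the third. Among the measured compounds shown here, none has a readable size, so no measured step can be carried over.

What is expected is a step that the limit leaves unreadable from compound 3 to compound 4 with no direction favoured and nothing beyond the scatter. A report of compound 4 as a limit only would be the likeliest outcome, as it has been for all three measured compounds. Compound 4 is expected at 30000 nM with an estimated range of 12000 nM to 60000 nM in this assay as well.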

Compound 4, half-maximal cytotoxic concentration: > 24000 nM
Compound 4: a limit, no number; the forecaster's own chance of this, stated with the estimate: 80%; the middle value lies beyond the limit too.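

Compound 4 is also reported only as a limit, > 24000 nM, in this assay. Among these compounds, compound 1, compound 2 and compound 3 are limits as well, so no step from any of them to compound 4 can be read. The compounds shown leave open whether changing the group on this aromatic carbon alters the read-out in this assay at all.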